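The source may hold more compounds than are shown below. What is called first, only, known or untested is meant among the compounds shown, and "the series" means these compounds.

Working notes on the series.

Compound 1 `Cc1cc(C)c(S(C)(=O)=O)cc1C(=O)N=C(N)N` gives 11 nM in a functional assay for inhibition of sodium/hydrogen exchanger (Oryctolagus cuniculus); a higher number here means a weaker inhibitor, a lower number a stronger inhibitor. Compound 2 `CCCCCc1cc(C)c(C(=O)N=C(N)N)cc1S(C)(=O)=O` gives 27 nM in this assay, and compound 3 `Cc1cc(Sc2ccncc2)c(S(C)(=O)=O)cc1C(=O)N=C(N)N` gives 13 nM. Among the three numbers compound 3 stands second highest, with compound 1 nearest and compound 2 furthest: the step from compound 1 to compound 3 is a 1.2-fold higher number from compound 1 to compound 3 (0.07 log units; within the scatter), while the step from compound 2 to compound 3 is a 2.1-fold lower number from compound 2 to compound 3 (0.32 log units; beyond the scatter), and the step from compound 1 to compound 2 is a 2.5-fold higher number from compound 1 to compound 2 (0.39 log units; beyond the scatter).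

Compound 4 `Cc1cc(Oc2ccc(Cl)cc2)c(S(C)(=O)=O)cc1C(=O)N=C(N)N` is not yet measured. It differs from compound 3 at one site: 4-chlorophenoxy in place of (pyridin-4-yl)sulfanyl on an aromatic carbon. The change sits on an aromatic carbon of the shared core, ortho to a methylsulfonyl group and para to a group of 6 heavy atoms.

Among the compounds with values here, two measured steps touch this site. The replacement of methyl by (pyridin-4-yl)sulfanyl, from compound 1 to compound 3, stayed within the scatter; the replacement of pentyl by (pyridin-4-yl)sulfanyl, from compound 2 to compound 3, gave a modest lower number. Within the data shown here, no measured pair compares an aryl ether with an aryl thioether at this position. The site thus appears tolerant of a range of groups, and for the exchange to 4-chlorophenoxy no step beyond the scatter is expected in this assay. Compound 4 is therefore estimated at 15 nM, within 6 nM to 40 nM; the expected step is a 1.2-fold higher number from compound 3 to compound 4 (0.06 log units; within the scatter).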

Compound 4, half-maximal inhibitory concentration: 13 nM
Estimate against measurement, compound 4: 1.2-fold (0.06 log units) above; low and high end bracket the measured number.
By their numbers in this assay, from the lowest: compounds 1, 3 and 4 (each within the scatter of the next); then compound 2.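

In this assay, within the data shown here, the first comparison of an aryl ether with an aryl thioether at this position gives (no change at the digits printed from compound 3 to compound 4 (within the scatter)), although the linking atom and the ring change together, with the ring nitrogen leaving and a chlorine entering. The larger 4-chlorophenoxy group also shows no step beyond the scatter against the methyl group of compound 1 (a 1.2-fold higher number from compound 1 to compound 4 (0.07 log units; within the scatter)), so the position now holds methyl, (pyridin-4-yl)sulfanyl and 4-chlorophenoxy with numbers that remain within the scatter of each other, while compound 2, with pentyl, goes against this tolerance (a 2.1-fold lower number from compound 2 to compound 4 (0.32 log units; beyond the scatter)). Nothing available on these compounds accounts for this tolerance.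

The compounds shown do not separate the exchange of sulfur for oxygen from the exchange of the pyridine ring for the chlorinated benzene ring, so the two could contribute separately or offset one another within this single step. Also open, on these data alone, is how an amine such as piperidine, a carboxylic acid or an unsubstituted phenoxy group at this position would read in this assay, and whether a chain shorter than pentyl would stay level with methyl.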